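This account rests on a few compounds, and the source may have more. Where it says the series, first, only, none or still open, it means among the compounds named here.

Measured compounds in a functional assay on SMMC-7721 cells (Homo sapiens) for cytotoxicity, read by MTT assay, with a stated time of 72 h; a lower number here means a stronger inhibitor, a higher number a weaker inhibitor:

Compound 1 `CCNC(=O)N1CCN(C(=S)SCc2cn(Cc3ccc(F)cc3)nn2)CC1`: in this assay compound 1 gives 44400 nM.
Compound 2 `CC(C)NC(=O)N1CCN(C(=S)SCc2cn(Cc3ccc(F)cc3)nn2)CC1`: in this assay compound 2 gives 5970 nM.
Compound 3 `O=C(NC1CCCCC1)N1CCN(C(=S)SCc2cn(Cc3ccc(F)cc3)nn2)CC1`: in this assay compound 3 reports only a limit of the assay, > 128000 nM; this is the limit noted as the limit of > 128000 nM in this assay, at which 1 of the 3 values shown sits.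

Compound 2 holds the lowest of the two numbers; its nearest neighbour is compound 1, with a 7.4-fold lower number from compound 1 to compound 2 (0.87 log units; beyond the scatter). The other steps among the measured compounds, an at least 2.8-fold higher number from compound 1 to compound 3 (0.45 log units; beyond the scatter) and an at least 21-fold higher number from compound 2 to compound 3 (1.33 log units; beyond the scatter), likewise concern only the group on the urea nitrogen of the shared core.

Compound 4 `COc1ccc(Cn2cc(CSC(=S)N3CCN(C(=O)NC(C)C)CC3)nn2)cc1` differs from compound 2 in methoxy in place of fluoro on an aromatic carbon. Within the data shown here, none of the measured steps changes anything on that aromatic ring, so no measured step bears directly on this change; the three steps so far are confined to the urea substituent. Among the measured compounds shown here, with no step on this part of the molecule to lean on, the expected change is none beyond the scatter, estimated as a 1.0-fold higher number from compound 2 to compound 4 (0.00 log units; within the scatter). Compound 4 is therefore expected to give about 6000 nM in this assay, within a range of 2000 nM to 20000 nM.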

Compound 4, half-maximal inhibitory concentration: > 128000 nM
Compound 4 gave a limit, no number (the forecaster's own chance of this, stated with the estimate: 10%); at least 21-fold (1.32 log units) between middle value and limit.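

In this assay, the benzyl group proves not to be a silent part of the series: all earlier steps lay on the urea nitrogen, and the change from 4-fluorobenzyl to 4-methoxybenzyl gives an at least 21-fold higher number from compound 2 to compound 4 (1.33 log units; beyond the scatter). Compound 4 gives > 128000 nM, which is a limit of the assay and not a number, so this step has only a lower bound. Changes in two different places, the cyclohexyl group of compound 3 and the methoxy group of compound 4, now end at the same limit: the limit of > 128000 nM in this assay, at which 2 of the 4 values shown sit.

Only fluoro and methoxy are shown on this aromatic carbon, so it stays open whether the step is particular to methoxy or follows from replacing fluoro at all. Chloro, methyl or hydroxy at this place, or plain hydrogen, would help to separate these two readings.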